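A few compounds are considered here, and "the series" means these few. Any claim that something is new, unique, unknown or untested is made for them only; others in the source may bear on it.

Measured so far:
- compound 1 `COc1cccc(N(C)C(=O)c2ccc(-c3ccc(C)c(C)c3)cc2)c1`: 75%
- compound 2 `Cc1cccc(N2CCN(S(=O)(=O)c3cccc(O)c3)CC2)c1`: 27%

Both compounds were tested in an assay on microsomes from placenta for inhibition of 17-beta-hydroxysteroid dehydrogenase type 2 (Homo sapiens), read by HPLC, with a stated time of 20 min, tested at 1 uM; on this read-out higher numbers stand for more inhibition at the one concentration tested (going by the name of the read-out) and lower numbers for less inhibition. Compound 1 gives 75%, the higher of the two numbers. Compound 2 gives 27%, a number far enough below compound 1 that the gap lies beyond the usual scatter of this assay. Among the compounds with values here, no pair of compounds measured here differs in only one place, so no single structural change has yet been tied to a change in the read-out.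

The next compound, compound 3 `COc1cccc(N(C)C(=O)c2ccc(Oc3ccc(Cl)cc3)cc2)c1`, keeps the core of compound 1 and changes one group: 4-chlorophenoxy in place of 3,4-dimethylphenyl on an aromatic carbon. The change sits para to a large group. Without a measured step to lean on, the step from compound 1 to compound 3 is expected to be small and downward, possibly none beyond the scatter: a number 15 percentage points lower from compound 1 to compound 3 (beyond the scatter). Compound 3 is therefore estimated at 60%, with a range from 30% to 85%.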

Compound 3, a percentage reported as inhibition, at one concentration (the size of the read-out at that concentration, not a potency): 51%
Compound 3: middle estimate off by 9 percentage points, on the high side; measured number inside the range.
By their numbers in this assay, from the lowest: compound 2; then compound 3; then compound 1.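

In this assay this position responds to what is attached: 4-chlorophenoxy in place of 3,4-dimethylphenyl gives a number 24 percentage points lower from compound 1 to compound 3 (beyond the scatter). The two groups have the same count of heavy atoms and each holds one six-membered aromatic ring of carbon only, so the step appears even with the size of the group unchanged by that count. The swap still alters several things at once, since two methyl groups leave while an oxygen and a chlorine enter, and nothing available explains the lower number.

From the compounds shown here alone, it remains open whether the oxygen or the chlorine goes with the step, which a plain phenoxy group or a 4-chlorophenyl group on the same carbon could separate. Going by these compounds, how an amine or a carboxylic acid at this position would read is also open.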